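This account rests on a few compounds, and the source may have more. Where it says the series, first, only, none or still open, it means among the compounds named here.

Measured compounds:
`COc1ccc(-c2cs/c(=N\NC(=O)c3ccc(O)cc3)n2-c2ccc(OC)cc2OC)cc1` — compound 1 gives 3310 nM in a functional assay on CAKI-1 cells (Homo sapiens) for cytotoxicity, read by sulforhodamine B assay, with a stated time of 48 h; on this read-out lower numbers stand for stronger inhibition of growth and higher numbers for weaker inhibition of growth.
`O=C(c1ccc(O)cc1)n1nc(-c2c(Cl)cccc2Cl)sc1=S` — compound 2 gives 6030 nM in this assay.

Compound 1 carries the lower of the two numbers, yet compound 2 lies within the scatter of it, so no order between them is claimed. Compound 3 `COc1ccc(-n2c(-c3ccc(Cl)cc3)cs/c2=N\NC(=O)c2ccc(O)cc2)c(OC)c1` differs from compound 1 by chloro in place of methoxy on an aromatic carbon. Among the compounds with values here, no measured pair carries this change, so in this assay the step from compound 1 to compound 3 is expected to stay within the scatter, with no clear direction. Compound 3 is therefore estimated at 3000 nM, ranging from 1200 nM to 8000 nM. The expected step is a 1.1-fold lower number from compound 1 to compound 3 (0.04 log units; within the scatter).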

Compound 3, concentration for 50% growth inhibition: 22900 nM
Compound 3: the middle estimate sits 7.6-fold (0.88 log units) below what was measured; measured number above the stated range.
By their numbers in this assay, from the lowest: compounds 1 and 2 (each within the scatter of the next); then compound 3.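

In this assay, within the data shown here, the change from 4-methoxyphenyl to 4-chlorophenyl gives a 6.9-fold higher number from compound 1 to compound 3 (0.84 log units; beyond the scatter) and is the first step here to lie beyond the scatter. This position, on an aromatic carbon para to a large group, therefore responds to the group it carries, and of these two groups methoxy goes with the stronger inhibition of growth. No measurement at hand accounts for the size of this step.

From the compounds shown here alone, it remains open how an amine or a carboxylic acid would read at this position. Whether the step from methoxy to chloro would hold on another core also remains unsettled.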